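Ester to cyclopropylamide on the acrylate chain

The compounds below may be only part of what the source reports. "The series", "measured", "known", "first", "only" and "open" are said of these compounds alone.

Measured compounds:
compound 1, `CCOC(=O)/C=C/c1ccncc1-c1ccc2[nH]ccc2c1` — > 10000 nM
compound 2, `CCOC(=O)/C=C/c1ccncc1-c1ccc2ccccc2c1` — > 10000 nM
compound 3, `Cn1ncc2cc(-c3cnccc3/C=C/C(=O)O)ccc21` — > 10000 nM

In a functional assay on KB cells (Homo sapiens) for inhibition, read by sulforhodamine B assay, with a stated time of 72 h (on this read-out lower numbers stand for stronger inhibition of growth and higher numbers for weaker inhibition of growth), compound 1 gives > 10000 nM, which is a limit of the assay rather than a number. In this assay compound 2 gives > 10000 nM, again a limit. In this assay compound 3 gives > 10000 nM, also a limit. Compound 2 therefore stands nowhere in particular on the numbers shown: every value of the series sits at the limit of > 10000 nM in this assay, at which 3 of the 3 values shown sit, and no step between measured compounds can be computed.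

The unmeasured compound 4, `O=C(/C=C/c1ccncc1-c1ccc2ccccc2c1)NC1CC1`, differs from compound 2 by cyclopropylamino in place of ethoxy on a carbonyl carbon, on a carbonyl carbon whose other neighbours are a double-bonded chain carbon; cut one bond further out, the change reads ethoxycarbonyl to cyclopropylcarbamoyl. With only limits on either side of the series, no direction or size of step can be drawn from the measured compounds.

Because compound 2 reports only a limit > 10000 nM in this assay, the expectation for compound 4 is that it too will be weak. The expected step that the limit leaves unreadable from compound 2 to compound 4 is none beyond the scatter. Compound 4 is estimated at 15000 nM, with a range from 4000 nM to 60000 nM, and most likely reported as a limit.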

Compound 4, concentration for 50% growth inhibition: 6050 nM
Compound 4: the middle estimate sits 2.5-fold (0.39 log units) above what was measured, within the range that was stated.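

In this assay, for the compounds shown here, compound 4 gives 6050 nM, a true number, and so the carbonyl carbon of the acrylate chain is the first place where a change brings a value inside the measurable range. Cyclopropylamino in place of ethoxy on that carbonyl carbon gives an at least 1.6-fold lower number from compound 2 to compound 4 (0.21 log units; that floor lies within the scatter); this is a floor and not a measured size, so the full size of the step stays unread, and on the printed floor alone the change is not shown to exceed the scatter. The other compounds offer no number against which compound 4 can be set: the limit of > 10000 nM in this assay, at which 3 of the 4 values shown sit.

On these data alone, it remains open whether the gain belongs to the cyclopropyl ring or to the amide hydrogen, a question that a methylamino or a dimethylamino group on the same carbonyl carbon would help to separate. As far as these compounds go, it also remains open whether cyclopropylamino on the carbonyl carbon would bring a measurable value on the core of compound 1, where only the ethyl ester stands so far.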